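Replacing the ester chain with a phenylpropyl tail

A few compounds are considered here, and "the series" means these few. Any claim that something is new, unique, unknown or untested is made for them only; others in the source may bear on it.

Compound 1, `CCC1(Cc2ccccc2)OS(=O)(=O)C=C1OCC(=O)OC`: in an ADME assay on HEL cells (Homo sapiens) for cytotoxicity, with a stated time of 3 days (a higher number here means that more compound is tolerated, a lower number that less compound is tolerated), compound 1 gives > 200000 nM.
Compound 2, `CCCC1(Cc2ccccc2)OS(=O)(=O)C=C1OCc1ccccc1`: in this assay compound 2 gives 200000 nM.
Compound 3, `CCC1(Cc2ccccc2)OS(=O)(=O)C=C1OCC1CCCCC1`: in this assay compound 3 gives > 200000 nM.

For compound 1 the value in this assay is a limit of the assay, not a number. For compound 3 the value is likewise a limit. Compound 2 gives a number that sits at the same point, so all three compounds are undistinguished here; the limit of > 200000 nM in this assay, at which 2 of the 3 values shown sit, sums this up.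

Compound 4, `CCC1(Cc2ccccc2)OS(=O)(=O)C=C1OCCCCc1ccccc1`, differs from compound 1 by 3-phenylpropyl in place of methoxycarbonyl on a saturated chain carbon bound to an oxygen on an unsaturated carbon. Among the compounds with values here, the only measured step that bears on the same position is a step that the two limits leave unreadable from compound 1 to compound 3, and the two limits leave its size unreadable. Nothing in the three values suggests that compound 4 should move beyond the scatter in either direction, and the exchange of the methoxycarbonyl for 3-phenylpropyl is expected to leave compound 4 at the limit as well.

Compound 4 is therefore estimated at 200000 nM, within 100000 nM to 400000 nM. The expected step of a number no higher from compound 1 to compound 4 (the limit leaves the size open) is essentially none.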

Compound 4, half-maximal cytotoxic concentration: 99000 nM
Compound 4: the middle estimate sits 2.0-fold (0.31 log units) above what was measured, and the stated range ends above it.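

In this assay, within the data shown here, 3-phenylpropyl gives this position, on a saturated chain carbon bound to an oxygen on an unsaturated carbon, its only steps with a readable floor: an at least 2.0-fold lower number from compound 1 to compound 4 (0.30 log units; that floor lies within the scatter), and an at least 2.0-fold lower number from compound 3 to compound 4 (0.30 log units; that floor lies within the scatter). Going by these compounds, both steps start from a limit, so their full size stays open, and with each floor within the scatter the result gives only a hint that this exchange lowers the tolerated concentration. The other values at this position offer no number to set beside it: the limit of > 200000 nM in this assay, at which 2 of the 4 values shown sit.

The compounds shown leave open whether the aromatic ring of the tail or the chain that carries it goes with the lower number. A tail ending in an amine or a carboxylic acid, or a longer chain without the ring, would help separate the two.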